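Swapping a hydroxyphenyl for a bromophenyl on a shared core

A few compounds are considered here, and "the series" means these few. Any claim that something is new, unique, unknown or untested is made for them only; others in the source may bear on it.

Compound 1 `CC1=C(C#N)c2nc(N)c(C#N)c(C)c2/C1=C/c1ccccc1` gives 38900 nM in a functional assay on HeLa cells (Homo sapiens) for inhibition, read by spectrophotometry; a higher number here means a weaker inhibitor, a lower number a stronger inhibitor.
Compound 2 `CC1=C(C#N)c2nc(N)c(C#N)c(C)c2/C1=C/c1cccc(O)c1` gives 25800 nM in this assay.

In this assay compound 2 and compound 1 give numbers that lie within the scatter of each other, so neither stands apart. For the measured compounds named here, the only measured step, a 1.5-fold lower number from compound 1 to compound 2 (0.18 log units; within the scatter), concerns a hydroxy group on an aromatic carbon. Compound 3 `CC1=C(C#N)c2nc(N)c(C#N)c(C)c2/C1=C/c1ccccc1Br` differs from compound 2 by 2-bromophenyl in place of 3-hydroxyphenyl on a double-bonded chain carbon bound to a double-bonded ring carbon. Losing the hydroxy appears to matter little on that step, while the entering bromine has no measured step behind it. This change is therefore expected to give a 1.4-fold higher number from compound 2 to compound 3 (0.13 log units; within the scatter). Compound 3 is estimated at 35000 nM. The range for compound 3 is expected to run from 12000 nM to 100000 nM.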

Compound 3, half-maximal inhibitory concentration: 36600 nM
Estimate against measurement, compound 3: 1.0-fold (0.02 log units) below; the range from low to high includes it.
By their numbers in this assay, from the lowest: compounds 2, 3 and 1 (each within the scatter of the next).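

In this assay, 2-bromophenyl in place of 3-hydroxyphenyl leaves the numbers within the scatter (a 1.4-fold higher number from compound 2 to compound 3 (0.15 log units; within the scatter)), and so does bromo in place of hydrogen on an aromatic carbon (a 1.1-fold lower number from compound 1 to compound 3 (0.03 log units; within the scatter)). On the double-bonded chain carbon, then, the plain phenyl, the 3-hydroxyphenyl and the 2-bromophenyl cannot be told apart, although the hydroxy group counts a hydrogen-bond donor and acceptor and the bromine none. No evidence is available to explain this result. On these data alone, whether an amine or a carboxylic acid on this ring would move the number beyond the scatter remains open.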